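A few compounds are considered here, and "the series" means these few. Any claim that something is new, unique, unknown or untested is made for them only; others in the source may bear on it.

Of the compounds shown here, three with a shared core have been measured. Compound 1 `CCc1ncn2c(S)nncc12` carries an ethyl group and a sulfanyl group on that core. In a functional assay for inhibition, with Homo sapiens as the target (on this read-out higher numbers stand for weaker inhibition and lower numbers for stronger inhibition), compound 1 gives > 48000 nM, which is a limit of the assay and not a number. Compound 2 `CCc1ncn2c(O)nncc12` has hydroxy in place of sulfanyl on an aromatic carbon. In this assay compound 2 gives > 48000 nM, again only a limit. Compound 3 `Cc1ncn2c(O)nncc12` has hydrogen in place of methyl on a saturated chain carbon bound to an aromatic carbon. In this assay compound 3 gives > 48000 nM, likewise a limit. Compound 2 thus stands at the limit of > 48000 nM in this assay, at which 3 of the 3 values shown sit. The step that the two limits leave unreadable from compound 1 to compound 2 and the step that the two limits leave unreadable from compound 2 to compound 3 cannot be read in size or direction.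

Compound 4 `C=CCSc1nncc2c(CC)ncn12` differs from compound 2 by allylsulfanyl in place of hydroxy on an aromatic carbon. Among the compounds with values here, no measured step shows a readable size, so the expectation rests only on the three limits. For compound 4 the step that the limit leaves unreadable from compound 2 to compound 4 is expected to stay near the limit. Compound 4 is estimated at 60000 nM, with a range from 15000 nM to 250000 nM.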

Compound 4, half-maximal inhibitory concentration: > 48000 nM
Compound 4 gave a limit, no number; the forecaster's own chance of this, stated with the estimate: 75%; the middle value is on the limit's open side.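

Compound 4 also gives only a limit, so neither its step from compound 2 nor its step from compound 1 can be read in size or direction. The compounds shown leave open which change to the shared core, if any, would give a readable value in this assay.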